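Pyrazole series: chlorothiophene in place of chlorophenyl

The compounds below may be only part of what the source reports. "The series", "measured", "known", "first", "only" and "open" are said of these compounds alone.

Compound 2 `COc1ccccc1-n1nc(C2CC(C)(C)OC(C)(C)C2)cc1-c1ccc(Cl)cc1` gives 16 nM in an assay on HEK293 cells for inhibition of Voltage-dependent N-type calcium channel subunit alpha-1B (Homo sapiens), read by patch clamp, using a membrane potential dye (a lower number here means a stronger inhibitor, a higher number a weaker inhibitor), the lowest of the two numbers measured. Compound 1 `COc1ccccc1-n1nc([C@@H]2CCO[C@H](C(C)C)C2)cc1-c1ccc(Cl)cc1` gives 55000 nM in this assay, and the step of a 3400-fold lower number from compound 1 to compound 2 (3.54 log units; beyond the scatter) separates them. Compound 3 `COc1ccccc1-n1nc([C@@H]2CCO[C@@H](C(C)C)C2)cc1-c1ccc(Cl)cc1` shows "not determined" (no result reported) in this assay, and only the fact that compounds 1 and 3 differ only in the configuration as drawn distinguishes it from compound 1. Compound 4 `COc1ccccc1-n1nc(C2CC(C)(C)OC(C)(C)C2)cc1-c1csc(Cl)c1` is the next entry to be measured. Its change from compound 2 is 5-chlorothiophen-3-yl in place of 4-chlorophenyl on an aromatic carbon. Among the compounds with values here, the only measured step, from compound 1 to compound 2, alters the saturated ring and says nothing about exchange of the aryl group, so no measured step bears directly on this change. With the tetramethyloxanyl group of compound 2 kept, the step is expected to be small in this assay, with a modest loss of potency more likely than a gain, so the expected step of a 1.9-fold higher number from compound 2 to compound 4 (0.27 log units; within the scatter) stays near the scatter. Compound 4 is estimated at 30 nM in this assay, with a range from 8 nM to 150 nM.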

Compound 4, half-maximal inhibitory concentration: 28 nM
The estimate for compound 4 lay 1.1-fold (0.03 log units) above the measured number; the measured number falls inside the stated range.
By their numbers in this assay, from the lowest: compounds 2 and 4 (each within the scatter of the next); then compound 1.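

Exchanging 4-chlorophenyl for 5-chlorothiophen-3-yl with the 2,2,6,6-tetramethyloxan-4-yl group kept gives a 1.8-fold higher number from compound 2 to compound 4 (0.24 log units; within the scatter) in this assay at this position. Within the data shown here, this is the first reading on the aryl group rather than the saturated ring, and it shows that one five-membered aromatic ring with 1 hetero atom and one six-membered aromatic ring of carbon only cannot be told apart here. Nothing measured on these compounds explains the result.

From the compounds shown here alone, whether the chlorine itself matters remains open, since a methyl or a nitrile in its place on the thiophene would be needed to tell. Also open, going by these compounds, is whether the same exchange holds when the saturated ring carries 2-isopropyl instead of the four methyl groups.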